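The source may report more compounds than this note shows. Statements on the series, on what has been measured and on what is new or still open speak of the compounds shown alone.

The measured compounds and their values in an assay on HeLa cells with Bile acid receptor (Homo sapiens) as the target, read by a luciferase reporter, with a stated time of 24 h; on this read-out higher numbers stand for an effect only at larger amounts of compound and lower numbers for an effect already at smaller amounts:

compound 1, `CC(C)(C)c1ccc(C(=O)NCc2ccc(C(N)=O)cc2)cc1`: 3800 nM
compound 2, `CC(C)Oc1ccc(CNC(=O)c2ccc(C(C)(C)C)cc2)cc1`: 170 nM
compound 3, `CSc1ccc(CNC(=O)c2ccc(C(C)(C)C)cc2)cc1`: 100 nM

Compound 3 gives the lowest number of the three. Against compound 2, however, the gap a 1.7-fold lower number from compound 2 to compound 3 (0.23 log units; within the scatter) lies within the scatter, so the two cannot be ranked; only compound 1 stands clearly apart, as the step of a 38-fold lower number from compound 1 to compound 3 (1.58 log units; beyond the scatter) shows.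

Compound 4 is `CC(C)(C)c1ccc(C(=O)NCc2ccc(S(C)(=O)=O)cc2)cc1`. It differs from compound 3 in one place: methylsulfonyl in place of methylsulfanyl on an aromatic carbon. For the measured compounds named here, no measured step exchanges these two groups directly. Going by the values given here, the steps that bear on it are a 22-fold lower number from compound 1 to compound 2 (1.35 log units; beyond the scatter) and a 38-fold lower number from compound 1 to compound 3 (1.58 log units; beyond the scatter), in which the carbamoyl of compound 1 gave way to a small group lacking double bonds and the numbers fell sharply. Compound 4 moves partly back in that direction, since the entering methylsulfonyl is, like carbamoyl, a group with double bonds outside the ring and more acceptors than methylsulfanyl. A rise in the number is therefore expected in this assay, though less than the full distance back to compound 1. The entering group is not carbamoyl, and the rise is expected to stop short of the number of compound 1. Compound 4 is estimated at 1200 nM, with a range from 350 nM to 4500 nM. That estimate amounts to a step of a 12-fold higher number from compound 3 to compound 4 (1.08 log units; beyond the scatter), beyond the scatter.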

Compound 4, half-maximal effective concentration: 3800 nM
Estimate against measurement, compound 4: 3.2-fold (0.50 log units) below, within the range that was stated.
By their numbers in this assay, from the lowest: compounds 3 and 2 (each within the scatter of the next); then compounds 1 and 4 (each within the scatter of the next).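

In this assay, placing oxygens on the sulfur of the methylsulfanyl group, on an aromatic carbon para to a large group, gives a 38-fold higher number from compound 3 to compound 4 (1.58 log units; beyond the scatter), so a change that leaves the sulfur and its methyl in place can still move the number by a large step. For the compounds shown here, the same exchange measured against the other small group gives a 22-fold higher number from compound 2 to compound 4 (1.35 log units; beyond the scatter), while the comparison with the first compound gives no change at the digits printed from compound 1 to compound 4 (within the scatter), which shows that the high number is not confined to carbamoyl: two different groups at this position now cannot be told apart in this read-out. No measurement here explains why the number rises with methylsulfonyl at this position.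

The compounds shown leave open where methylsulfinyl, which has fewer oxygens on the sulfur, would fall on the way from methylsulfanyl to methylsulfonyl, and so whether the number rises gradually or in one jump. They also leave open whether a nitrile, a carboxylic acid or an amine at this position would land with compound 1 and compound 4 or with compound 2 and compound 3.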